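Replacing a Nitro Group by Trifluoromethyl on the Benzyl Ether

The compounds below may be only part of what the source reports. "The series", "measured", "known", "first", "only" and "open" are said of these compounds alone.

Measured so far:
Compound 1 `COc1cc(OC)c(-c2coc3cc(OCc4ccccc4F)ccc3c2=O)cc1OC` gives 2900 nM in a functional assay on HCT-116 cells (Homo sapiens) for antiproliferative activity, read by MTT assay, with a stated time of 24 h; on this read-out lower numbers stand for stronger inhibition and higher numbers for weaker inhibition.
Compound 3 `COc1cc(OC)c(-c2coc3cc(OCc4cccc(F)c4)ccc3c2=O)cc1OC` gives 4920 nM in this assay.
Compound 2 `COc1cc(OC)c(-c2coc3cc(OCc4ccc([N+](=O)[O-])cc4)ccc3c2=O)cc1OC` reaches only the assay limit > 10000 nM in this assay.

The three compounds share one core and differ only in the group on a saturated chain carbon bound to an oxygen on an aromatic ring. Compound 2 stands at the limit of > 10000 nM in this assay, at which 1 of the 3 values shown sits, so its true position is known only as a limit, not as a number.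

Compound 4 `COc1cc(OC)c(-c2coc3cc(OCc4cccc(C(F)(F)F)c4)ccc3c2=O)cc1OC` has not yet been measured. It differs from compound 2 by one change: 3-(trifluoromethyl)phenyl in place of 4-nitrophenyl on a saturated chain carbon bound to an oxygen on an aromatic ring.

Among the compounds with values here, two measured steps bear on this change, since each also exchanges the 4-nitrophenyl group for a ring carrying a small substituent. There was an at least 3.4-fold higher number from compound 1 to compound 2 (0.53 log units; beyond the scatter), and an at least 2.0-fold lower number from compound 2 to compound 3 (0.30 log units; that floor lies within the scatter). Both point the same way: the 4-nitrophenyl compound sits at the weak end, and a fluorinated ring in its place gives a lower number. The 3-(trifluoromethyl)phenyl group is expected to behave like the 3-fluorophenyl group of compound 3, so a lower number than the limit of compound 2 is expected, though with a real chance that the assay again reports only a limit.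

Compound 4 is therefore estimated at 5000 nM in this assay, with a range from 2000 nM to 12000 nM, which corresponds to an expected at least 2.0-fold lower number from compound 2 to compound 4 (0.30 log units; that floor lies within the scatter).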

Compound 4, half-maximal inhibitory concentration: 3400 nM
The estimate for compound 4 lay 1.5-fold (0.17 log units) above the measured number; the measured number falls inside the stated range.
By their numbers in this assay, from the lowest: compounds 1, 4 and 3 (each within the scatter of the next). At a limit, above all of these: compound 2.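

In this assay, the new step is an at least 2.9-fold lower number from compound 2 to compound 4 (0.46 log units; beyond the scatter), and this clears the scatter, whereas the floor of an at least 2.0-fold lower number from compound 2 to compound 3 (0.30 log units; that floor lies within the scatter) did not, so a ring other than 4-nitrophenyl at this position is now clearly separated from compound 2. Changing the ring substituent itself makes no difference that can be read: a 1.4-fold lower number from compound 3 to compound 4 (0.16 log units; within the scatter), and a 1.2-fold higher number from compound 1 to compound 4 (0.07 log units; within the scatter), so compounds 1, 3 and 4 form one group within the scatter, with compound 2 the only one of the four standing apart. Compound 2 is still known only as a limit, so its step to compound 4 has a floor but no exact size: the limit of > 10000 nM in this assay, at which 1 of the 4 values shown sits.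

The names 4-nitrophenyl and 3-(trifluoromethyl)phenyl differ both in the substituent and in its number on the ring, so the compounds shown cannot tell whether the nitro group itself or its place on the ring sets compound 2 apart. They also leave open how a ring bearing an amine or a carboxylic acid, or a longer chain in place of the benzyl group, would read in this assay.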